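This account rests on a few compounds, and the source may have more. Where it says the series, first, only, none or still open, it means among the compounds named here.

Measured compounds:
- compound 1 `CN1CCN(c2ccc(C3=NN(C(=O)c4ccc(C(F)(F)F)cc4)C(c4ccc(N(C)C)cc4)C3)cc2)CC1`: 84.1%
- compound 2 `CN1CCN(c2ccc(C3=NN(S(C)(=O)=O)C(c4ccc(N(C)C)cc4)C3)cc2)CC1`: -18.5%
- compound 3 `CN(C)c1ccc(C2CC(c3ccc(-n4ccnc4)cc3)=NN2C(=O)c2ccc(C(F)(F)F)cc2)cc1`: 28%

All three numbers come from a functional assay on HCC1806 cells (Homo sapiens) for inhibition, read by sulforhodamine B assay, tested at 10 uM; a lower number here means less inhibition, a higher number more inhibition at the concentration tested (going by the name of the read-out). Within this set, compound 1 stands highest and compound 2 lowest, both beyond the scatter from every other member.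

The change methylsulfonyl in place of (4-(trifluoromethyl)phenyl)carbonyl on an amine nitrogen in a ring produced a number 102.6 percentage points lower from compound 1 to compound 2 (beyond the scatter). The cores of compound 1 and compound 3 differ by 1H-imidazol-1-yl in place of 4-methylpiperazin-1-yl on an aromatic carbon, which produced a number 56.1 percentage points lower from compound 1 to compound 3 (beyond the scatter).

Compound 4 `CN(C)c1ccc(C2CC(c3ccc(-n4ccnc4)cc3)=NN2S(C)(=O)=O)cc1` is not yet measured in this assay. It carries the same kind of change on the core of compound 3, (methylsulfonyl in place of (4-(trifluoromethyl)phenyl)carbonyl on an amine nitrogen in a ring). The surroundings are not identical word for word: in compound 1 the ring atom two ring bonds away bears a large group, in compound 3 it bears a 4-(1H-imidazol-1-yl)phenyl group.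

The step expected from compound 3 to compound 4 is a number 43 percentage points lower from compound 3 to compound 4 (beyond the scatter), estimated smaller than the earlier one because compound 3 starts from 28% and compound 2 already sits at -18.5%, so a fall of the full earlier size is not expected. For compound 4 the estimate is -15%, expected between -45% and 15%.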

Compound 4, a percentage reported as inhibition, at one concentration (the size of the read-out at that concentration, not a potency): 11.3%
Estimate against measurement, compound 4: 26.3 percentage points below; the measured number falls inside the stated range.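

In this assay, methylsulfonyl in place of (4-(trifluoromethyl)phenyl)carbonyl on the core carrying the 1H-imidazol-1-yl group gives a number 16.7 percentage points lower from compound 3 to compound 4 (beyond the scatter), the same direction as on the core carrying the 4-methylpiperazin-1-yl group but not the same size: the same change on two cores in this assay, a number 102.6 percentage points lower (beyond the scatter) from compound 1 to compound 2 and a number 16.7 percentage points lower (beyond the scatter) from compound 3 to compound 4, 85.9 percentage points apart, beyond the scatter of two such steps. The other change, 1H-imidazol-1-yl in place of 4-methylpiperazin-1-yl, gives a number 29.8 percentage points higher from compound 2 to compound 4 (beyond the scatter) with methylsulfonyl on the ring nitrogen, and its direction reverses between the two cores: the same change on two cores in this assay, a number 56.1 percentage points lower (beyond the scatter) from compound 1 to compound 3 and a number 29.8 percentage points higher (beyond the scatter) from compound 2 to compound 4, 85.9 percentage points apart, beyond the scatter of two such steps. Within these four compounds, the effect of each change therefore depends on the group at the other place, so neither step can simply be carried to another core, but the set does not show what underlies this dependence.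

On these data alone, it remains open whether the same dependence appears with an acetyl or unsubstituted benzoyl group on the ring nitrogen, or with a morpholine in place of the 4-methylpiperazin-1-yl group. As far as these compounds go, how these single-concentration readings relate to potency also remains open.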